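Swapping a Hydroxybutyl Urea for a Piperidine Amide

The source may report more compounds than this note shows. Statements on the series, on what has been measured and on what is new or still open speak of the compounds shown alone.

- Compound 1 `O=C(c1ccccc1)c1ccc2nc(NCCC3CCCNC3)[nH]c2c1` reaches in an ADME assay on HL-60 cells (Homo sapiens) for cytotoxicity, read by resazurin assay, with a stated time of 72 h (on this read-out lower numbers stand for an effect already at smaller amounts and higher numbers for an effect only at larger amounts of compound), only a limit, > 30000 nM.
- Compound 2 `O=C(NCCCCO)Nc1nc2ccc(C(=O)c3ccccc3)cc2[nH]1` reaches in this assay only a limit, > 30000 nM.
- Compound 3 `NCCCCCCC(=O)Nc1nc2ccc(C(=O)c3ccccc3)cc2[nH]1` reaches in this assay only a limit, > 30000 nM.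

Compound 2 therefore stands where every measured compound stands, at the limit described by the limit of > 30000 nM in this assay, at which 3 of the 3 values shown sit. Because of the limit of > 30000 nM in this assay, at which 3 of the 3 values shown sit, the steps a step that the two limits leave unreadable from compound 1 to compound 2 and a step that the two limits leave unreadable from compound 2 to compound 3 cannot be given a size. Compound 4 `O=C(CCCC1CCNCC1)Nc1nc2ccc(C(=O)c3ccccc3)cc2[nH]1` differs from compound 2 by 3-(piperidin-4-yl)propyl in place of (4-hydroxybutyl)amino on a carbonyl carbon. Among the measured compounds shown here, no measured step offers a readable size, so no shift beyond the scatter is expected. Compound 4 is expected to sit at the limit as well, estimated at 40000 nM, from 15000 nM to 100000 nM. The expected step that the limit leaves unreadable from compound 2 to compound 4 is thus estimated to lie within the scatter.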

Compound 4, half-maximal effective concentration: > 30000 nM
Compound 4 gave a limit, no number (the forecaster's own chance of this, stated with the estimate: 75%); the middle value does not contradict the limit.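

The steps from compound 2 and from compound 3 to compound 4 cannot be read, since all of these results are limits rather than numbers: the limit of > 30000 nM in this assay, at which 4 of the 4 values shown sit.

The compounds shown leave open at what concentration any of them acts in this assay, and whether their side chains differ there at all.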